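Swapping a benzylic hydroxyl for dimethylamine in compound 4

This account rests on a few compounds, and the source may have more. Where it says the series, first, only, none or still open, it means among the compounds named here.

Compound 1, `CC[C@H](C)[C@H](N)CN(C(=O)[C@@H]1C[C@H]1c1ccccc1)c1ccc(-c2ccc(OC)cc2)cc1`, gives 120 nM in a functional assay for agonist activity at G protein-coupled receptor 88 (Homo sapiens), read by HTRF and cAMP accumulation; on this read-out higher numbers stand for an effect only at larger amounts of compound and lower numbers for an effect already at smaller amounts.
Compound 2, `CC[C@H](C)[C@H](N)CN(C(=O)[C@@H]1C[C@H]1c1ccccc1)c1ccc(-c2ccc(COC(C)(C)C)cc2)cc1`, gives 280 nM in this assay.
Compound 3, `CC[C@H](C)[C@H](N)CN(C(=O)[C@@H]1C[C@H]1c1ccccc1)c1ccc(-c2ccc(CO)cc2)cc1`, gives 1100 nM in this assay.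

Compound 3 stands highest of the three: a 9.2-fold higher number from compound 1 to compound 3 (0.96 log units; beyond the scatter) and a 3.9-fold higher number from compound 2 to compound 3 (0.59 log units; beyond the scatter) both run against it. Compound 4, `CC[C@H](C)[C@H](N)CN(C(=O)[C@@H]1C[C@H]1c1ccccc1)c1ccc(-c2ccc(CN(C)C)cc2)cc1`, carries dimethylamino in place of hydroxy on a saturated chain carbon bound to an aromatic carbon. Among the measured compounds shown here, no measured step makes this exact exchange, but the two steps that alter the group on that same carbon, a 2.3-fold higher number from compound 1 to compound 2 (0.37 log units; beyond the scatter) and a 3.9-fold higher number from compound 2 to compound 3 (0.59 log units; beyond the scatter), were modest, and the single hydrogen-bond donor counted in compound 3 leaves again here, as it was absent in compound 2. A modest fall of the number is therefore expected for compound 4, a 2.8-fold lower number from compound 3 to compound 4 (0.44 log units; beyond the scatter), giving an estimated 400 nM with a range from 120 nM to 1300 nM.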

Compound 4, half-maximal effective concentration: 460 nM
For compound 4 the middle estimate is 1.2-fold (0.06 log units) below the measured one; low and high end bracket the measured number.
By their numbers in this assay, from the lowest: compound 1; then compounds 2 and 4 (each within the scatter of the next); then compound 3.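

In this assay, putting dimethylamino in place of hydroxy on this saturated chain carbon recovers part of the loss seen with the hydroxymethyl group, a 2.4-fold lower number from compound 3 to compound 4 (0.38 log units; beyond the scatter), though a 3.8-fold higher number from compound 1 to compound 4 (0.58 log units; beyond the scatter) shows that the methoxy group still gives the lowest number. Dimethylamino and tert-butoxy cannot be told apart here, a 1.6-fold higher number from compound 2 to compound 4 (0.22 log units; within the scatter), so a nitrogen-linked and an oxygen-linked group can serve equally at this position. Nothing measured explains these steps. On these data alone, whether a primary amine, a cyclic amine such as morpholine or a carboxylic acid would fit as well stays open.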